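Replacing the methoxy of compound 3 with a long amide

This account rests on a few compounds, and the source may have more. Where it says the series, first, only, none or still open, it means among the compounds named here.

In a functional assay on U-373MG ATCC cells (Homo sapiens) for inhibition, read by colorimetric assay and MTT assay, with a stated time of 72 h (on this read-out higher numbers stand for weaker inhibition and lower numbers for stronger inhibition), compound 3 (`C=CCCCCOc1ccccc1-c1cnc(OC)n1C`) gives > 100000 nM, which is a limit and not a number. Its place is therefore known only as the limit of > 100000 nM in this assay, at which 1 of the 3 values shown sits. Two relatives with the same shared core give numbers: compound 1 (`C=CCCCCOc1ccccc1-c1cnc(OCCC=C)n1C`) reads 33000 nM and compound 2 (`C=CCCCCOc1ccccc1-c1cnc(OCCCCC=C)n1C`) reads 7000 nM.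

Compound 4 (`C=CCCCCOc1ccccc1-c1cnc(NC(=O)CCCC=C)n1C`) carries ((pent-4-en-1-yl)carbonyl)amino in place of methoxy on an aromatic carbon, between two ring nitrogen atoms: ((pent-4-en-1-yl)carbonyl)amino in place of methoxy on an aromatic carbon.

For the measured compounds named here, three measured steps bear on this change. Removing the allyl group gives an at least 3.0-fold higher number from compound 1 to compound 3 (0.48 log units; beyond the scatter), and removing the pent-4-en-1-yl group gives the larger at least 14-fold higher number from compound 2 to compound 3 (1.15 log units; beyond the scatter). The two chains themselves differ by a 4.7-fold lower number from compound 1 to compound 2 (0.67 log units; beyond the scatter). In these three compounds, the number falls as the group on the oxygen grows, and none goes against this. Going by the values given here, no measured compound has an amide at this place, so the link itself is untested.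

Compound 4 keeps a pent-4-en-1-yl group, and the closest guide is the step of an at least 14-fold higher number from compound 2 to compound 3 (1.15 log units; beyond the scatter), so a large move to a lower number is expected in this assay, though probably not quite as far as compound 2. The expected change is an at least 6.6-fold lower number from compound 3 to compound 4 (0.82 log units; beyond the scatter). For compound 4 the estimated value is 15000 nM, with an expected range from 4000 nM to 60000 nM.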

Compound 4, half-maximal inhibitory concentration: 7000 nM
Compound 4: middle estimate off by 2.1-fold (0.33 log units), on the high side, and the stated range covers the measured number.
By their numbers in this assay, from the lowest: compounds 2 and 4 (each within the scatter of the next); then compound 1. At a limit, above all of these: compound 3.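

In this assay an amide link on this aromatic carbon, between two ring nitrogen atoms, matches an ether link, with ((pent-4-en-1-yl)carbonyl)amino in place of (hex-5-en-1-yl)oxy giving no change at the digits printed from compound 2 to compound 4 (within the scatter) and so leaving the reading where the longer ether had it. The same group in place of (but-3-en-1-yl)oxy gives a 4.7-fold lower number from compound 1 to compound 4 (0.67 log units; beyond the scatter) and thereby shows that the low reading reached with a long chain on oxygen does not depend on that oxygen, as a long chain joined through an amide reaches it too. In place of methoxy it gives an at least 14-fold lower number from compound 3 to compound 4 (1.15 log units; beyond the scatter) as a step that starts from a limit and not from a number for compound 3: the limit of > 100000 nM in this assay, at which 1 of the 4 values shown sits.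

The compounds shown leave open whether the amide hydrogen matters, a question that an amide with a methyl group on its nitrogen, or a plain amine carrying the same chain, would address. They also leave open how far the chain itself counts, as an amide with a shorter or longer chain, or with a saturated chain ending in no double bond, would show.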